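A few compounds are considered here, and "the series" means these few. Any claim that something is new, unique, unknown or untested is made for them only; others in the source may bear on it.

Compound 1 `CC(C)c1noc(N2CCN(C(=O)[C@@H]3CCCN(S(=O)(=O)c4ccc(S(=O)(=O)C(C)C)cc4)C3)CC2)n1` gives 70 nM in a functional assay on MIA PaCa-2 cells (Homo sapiens) for inhibition, read by MTT assay, with a stated time of 7 days; a higher number here means a weaker inhibitor, a lower number a stronger inhibitor.
Compound 2 `CC(C)c1noc(N2CCN(C(=O)[C@@H]3CCCN(S(=O)(=O)c4ccc(S(=O)(=O)NC(C)(C)C)cc4)C3)CC2)n1` gives 300 nM.
Compound 3 `CCN(CC)C(=O)c1ccc(S(=O)(=O)N2CCC[C@@H](C(=O)N3CCN(c4nc(C(C)C)no4)CC3)C2)cc1` gives 100 nM.

Of these three numbers compound 3 stands second highest. Its nearest neighbour is compound 1, with a 1.4-fold higher number from compound 1 to compound 3 (0.15 log units; within the scatter), so the two cannot be told apart. Its furthest is compound 2, with a 3.0-fold lower number from compound 2 to compound 3 (0.48 log units; beyond the scatter).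

Compound 4 `CC(C)c1noc(N2CCN(C(=O)[C@@H]3CCCN(S(=O)(=O)c4ccc(S(=O)(=O)NC5CCC5)cc4)C3)CC2)n1` differs from compound 3 in one place: cyclobutylsulfamoyl in place of diethylcarbamoyl on an aromatic carbon. Among the compounds with values here, two measured steps bear on this. The first, a 4.3-fold higher number from compound 1 to compound 2 (0.63 log units; beyond the scatter), put a (tert-butyl)amino in place of isopropyl on a sulfonyl sulfur, and the number rose modestly. The second, a 3.0-fold lower number from compound 2 to compound 3 (0.48 log units; beyond the scatter), put diethylcarbamoyl in place of (tert-butyl)sulfamoyl and the number fell by a similar amount. The entering cyclobutylsulfamoyl group of compound 4 resembles the (tert-butyl)sulfamoyl of compound 2 far more than the diethylcarbamoyl it replaces, so the step from compound 3 to compound 4 is expected to run back in the direction of compound 2, a modest rise beyond the scatter. Compound 4 is therefore expected to show a 2.5-fold higher number from compound 3 to compound 4 (0.40 log units; beyond the scatter). Compound 4 is estimated at 250 nM, with a range from 120 nM to 550 nM.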

Compound 4, half-maximal inhibitory concentration: 600 nM
Beside the measured number, compound 4's estimate is 2.4-fold (0.38 log units) below it; measured number above the stated range.
By their numbers in this assay, from the lowest: compounds 1 and 3 (each within the scatter of the next); then compounds 2 and 4 (each within the scatter of the next).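

The cyclobutylsulfamoyl group on this aromatic carbon, para to a large group, separates clearly from the diethylcarbamoyl group in this assay, with a 6.0-fold higher number from compound 3 to compound 4 (0.78 log units; beyond the scatter), and from the isopropylsulfonyl group, with an 8.6-fold higher number from compound 1 to compound 4 (0.93 log units; beyond the scatter); compound 2 also stands apart from both compound 1 and compound 3, so among these four compounds both sulfamoyl groups go with higher numbers than either of the other two groups. The nitrogen substituent itself makes no readable difference here: cyclobutyl in place of tert-butyl gives a 2.0-fold higher number from compound 2 to compound 4 (0.30 log units; within the scatter), which leaves compound 2 and compound 4 indistinguishable, so the two sulfonamides read as one level rather than as a trend with the group on nitrogen. Nothing in hand gives a measured reason for the gap between the sulfonamides and the other two groups.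

The compounds shown leave open whether that gap follows the sulfonyl link or the hydrogen on the sulfonamide nitrogen, a question that a diethylsulfamoyl group at this position would address directly. They also leave open how a much smaller nitrogen substituent, such as methyl, or a plain unsubstituted sulfamoyl group would stand against the two sulfonamides.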